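Changing the Amine at the Chain End of Compound 2

The source may hold more compounds than are shown below. What is called first, only, known or untested is meant among the compounds shown, and "the series" means these compounds.

Two measured compounds share one core and differ only in the amine sitting on a saturated chain carbon, four bonds along the chain from an oxygen on an aromatic ring. Compound 1 `CCN(CC)CCCCOc1c(OCc2ccccc2)cc(O)c2c(=O)cc(-c3ccccc3)oc12` carries a diethylamino group there, and in a functional assay on MCF7 cells (Homo sapiens) for cytotoxicity, read by MTT assay, with a stated time of 72 h (on this read-out higher numbers stand for weaker inhibition and lower numbers for stronger inhibition), compound 1 gives 1920 nM. Compound 2 `O=c1cc(-c2ccccc2)oc2c(OCCCCN3CCCC3)c(OCc3ccccc3)cc(O)c12` carries a pyrrolidin-1-yl group instead, and in this assay compound 2 gives 1890 nM. The step of a 1.0-fold lower number from compound 1 to compound 2 (0.01 log units; within the scatter) shows that this exchange made no difference that can be told from the scatter, so compound 2 and compound 1 stand at numbers that cannot be told apart. Compound 3 `CN1CCN(CCCCOc2c(OCc3ccccc3)cc(O)c3c(=O)cc(-c4ccccc4)oc23)CC1` changes the same place once more: 4-methylpiperazin-1-yl in place of pyrrolidin-1-yl on a saturated chain carbon, four bonds along the chain from an oxygen on an aromatic ring. For the measured compounds named here, the only comparable step, a 1.0-fold lower number from compound 1 to compound 2 (0.01 log units; within the scatter), was flat, so a further amine swap on this chain is expected to give a step of about a 1.1-fold higher number from compound 2 to compound 3 (0.02 log units; within the scatter) in this assay. Compound 3 is therefore estimated at 2000 nM, within a range from 900 nM to 4500 nM.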

Compound 3, half-maximal inhibitory concentration: 2930 nM
Compound 3: middle estimate off by 1.5-fold (0.17 log units), on the low side; measured number inside the range.
By their numbers in this assay, from the lowest: compounds 2, 1 and 3 (each within the scatter of the next).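

For the compounds shown here, compound 3 extends the series to a larger group at the chain end, 4-methylpiperazin-1-yl, with a six-membered non-aromatic ring and 2 hetero atoms, whereas the earlier compounds carried only pyrrolidin-1-yl or diethylamino. In this assay this exchange gives a 1.6-fold higher number from compound 2 to compound 3 (0.19 log units; within the scatter) and, measured against the diethylamino group, a 1.5-fold higher number from compound 1 to compound 3 (0.18 log units; within the scatter) and both steps lie within the scatter, so the three amines stand at numbers that cannot be told apart. No measurement on hand explains why these amine exchanges leave the number within the scatter.

On these data alone, it remains open whether a morpholin-4-yl group or a simple primary amine at this place would also stay within the scatter, or whether a carboxylic acid in place of the amine would shift the number beyond it. A shorter or longer chain carrying these same amines is also an open question.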